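This account rests on a few compounds, and the source may have more. Where it says the series, first, only, none or still open, it means among the compounds named here.

Measured compounds, in a functional assay on HL-60 cells (Homo sapiens) for antiproliferative activity, read by MTT assay, with a stated time of 72 h; a lower number here means a stronger inhibitor, a higher number a weaker inhibitor:

compound 1 `CC(=O)N(C)c1ccc2[nH]c(-c3n[nH]c4ccccc34)cc2n1` gives 5110 nM
compound 2 `CN(C(=O)CCc1ccccc1)c1ccc2[nH]c(-c3n[nH]c4ccccc34)cc2n1` gives 4730 nM
compound 3 `CN(C(=O)c1ccco1)c1ccc2[nH]c(-c3n[nH]c4ccccc34)cc2n1` gives 4540 nM

Compound 3 sits at one end of these three numbers, but the steps of a 1.1-fold lower number from compound 1 to compound 3 (0.05 log units; within the scatter) and a 1.0-fold lower number from compound 2 to compound 3 (0.02 log units; within the scatter) are both within the scatter, so the three compounds cannot be told apart on this assay. The shared core has been held constant throughout, and only the group on the carbonyl carbon of the amide has been varied.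

Compound 4 `COc1ccc(NC(=O)N(C)c2ccc3[nH]c(-c4n[nH]c5ccccc45)cc3n2)cc1` continues this variation: (4-methoxyphenyl)amino in place of furan-2-yl on a carbonyl carbon. Going by the values given here, the steps that bear on it are those at the same carbonyl carbon, a 1.1-fold lower number from compound 1 to compound 2 (0.03 log units; within the scatter), a 1.1-fold lower number from compound 1 to compound 3 (0.05 log units; within the scatter) and a 1.0-fold lower number from compound 2 to compound 3 (0.02 log units; within the scatter), none of which moved the number beyond the scatter. Among the compounds with values here, nothing among the measured compounds shows that a group with a hydrogen-bond donor at this position behaves differently, so no step beyond the scatter is expected; the estimated step is a 1.0-fold higher number from compound 3 to compound 4 (0.02 log units; within the scatter). For compound 4 the expected value in this assay is 4700 nM, with a range from 1800 nM to 12500 nM.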

Compound 4, half-maximal inhibitory concentration: 7.9 nM
The estimate for compound 4 lay 590-fold (2.77 log units) above the measured number, outside the stated range (below it).
By their numbers in this assay, from the lowest: compound 4; then compounds 3, 2 and 1 (each within the scatter of the next).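

In this assay, going by these compounds alone, the group on the carbonyl carbon proves able to move the number strongly, which the earlier compounds gave no sign of: (4-methoxyphenyl)amino stands apart from furan-2-yl (a 570-fold lower number from compound 3 to compound 4 (2.76 log units; beyond the scatter)), from phenethyl (a 600-fold lower number from compound 2 to compound 4 (2.78 log units; beyond the scatter)) and from methyl (a 650-fold lower number from compound 1 to compound 4 (2.81 log units; beyond the scatter)). Methyl, phenethyl and furan-2-yl stay within the scatter of one another, so among these four groups only (4-methoxyphenyl)amino separates from the rest. No measurement available here bears on the reason for this step.

Going by these compounds, whether the step depends on the amino nitrogen, the aromatic ring or the methoxy group remains open. Phenylamino, methylamino and 4-methoxyphenyl on the same carbonyl carbon would each test one part of the entering group.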